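The source may hold more compounds than are shown below. What is called first, only, known or untested is meant among the compounds shown, and "the series" means these compounds.

Measured compounds:
compound 1, `COc1cccc2cc(C(=O)NCC(=O)O)c(=O)oc12`, 27%
compound 2, `O=C(O)CNC(=O)c1cc2ccccc2oc1=O`, 1%
compound 3, `O=C(NCCCN1CCN(CCCNC(=O)c2cc3ccccc3oc2=O)CC1)c1cc2ccccc2oc1=O`, 9%

In an assay on CHO cells for displacement of a labelled ligand from adenosine receptor A1 (Homo sapiens), read by scintillation counting, with a stated time of 60 min, tested at 10 uM (a lower number here means less inhibition, a higher number more inhibition at the concentration tested (going by the name of the read-out)), compound 1 gives the highest of the three numbers. Compound 3 gives 9%, a lower number beyond the scatter, and compound 2 gives 1%, the lowest. Within the data shown here, the only single-point step among the measured compounds is a number 26 percentage points lower from compound 1 to compound 2 (beyond the scatter), where the change is hydrogen in place of methoxy on an aromatic carbon.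

Compound 4, `COCCNC(=O)c1cc2cccc(OC)c2oc1=O`, keeps that methoxy and differs from compound 1 elsewhere: methoxymethyl in place of carboxy on a saturated chain carbon bound to an amide-type nitrogen. Among the measured compounds shown here, no measured step exchanges carboxy for methoxymethyl, so the step from compound 1 to compound 2 shows only that the shared core answers to a small change, not how this one will turn out. Without a direct precedent, a step within the scatter, in either direction, is the most defensible expectation, written as a number 5 percentage points lower from compound 1 to compound 4 (within the scatter). Compound 4 is therefore estimated at 22%, with a range from 2% to 45%.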

Compound 4, a percentage reported as inhibition, at one concentration (the size of the read-out at that concentration, not a potency): 45%
Compound 4: the middle estimate sits 23 percentage points below what was measured; the measured number falls inside the stated range.
By their numbers in this assay, from the lowest: compounds 2 and 3 (each within the scatter of the next); then compound 1; then compound 4.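

In this assay, the side chain turns out to matter as well as the aromatic methoxy: methoxymethyl in place of carboxy on a saturated chain carbon bound to an amide-type nitrogen gives a number 18 percentage points higher from compound 1 to compound 4 (beyond the scatter). With the methoxy kept, the carboxy group is therefore not required for inhibition at the tested concentration, and its replacement raises the reading, which the earlier step on the aromatic carbon could not show. The exchange removes the hydrogen-bond donor of carboxy, but nothing available shows whether that accounts for the rise.

On these data alone, it remains open whether a primary amine or a plain propyl chain at this place would raise the reading further or lower it. As far as these compounds go, it is also open whether methoxymethyl would give a similar step on the core without the aromatic methoxy.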